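Combining Two Inactive Pieces Into a Fourth Compound

The source may hold more compounds than are shown below. What is called first, only, known or untested is meant among the compounds shown, and "the series" means these compounds.

Compound 1 `CCc1nnc(SCC(=O)c2ccc(C)cc2)n1N1C(=O)c2ccccc2C1=O` in a functional assay on A549 cells (Homo sapiens) for cytotoxicity, read by MTT assay, with a stated time of 48 h (on this read-out lower numbers stand for stronger inhibition and higher numbers for weaker inhibition), gives > 200000 nM, which is a limit of the assay and not a number. Compound 2 `C=CCSc1nnc(-c2cc(OC)c(OC)c(OC)c2)n1N1C(=O)c2ccccc2C1=O` gives > 200000 nM, again only a limit. Compound 3 `COc1cc(-c2nnc(SCc3ccccc3Cl)n2N2C(=O)c3ccccc3C2=O)cc(OC)c1OC` gives > 200000 nM, also a limit.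

Compound 3 therefore stands at a limit, and no order among the three compounds can be read. Among the compounds with values here, the single step between measured compounds, a step that the two limits leave unreadable from compound 2 to compound 3, is unreadable because of the limit of > 200000 nM in this assay, at which 3 of the 3 values shown sit. Compound 4 `COc1cc(-c2nnc(SCC(=O)c3ccc(C)cc3)n2N2C(=O)c3ccccc3C2=O)cc(OC)c1OC` differs from compound 3 by (4-methylphenyl)carbonyl in place of 2-chlorophenyl on a saturated chain carbon bound to a sulfur. Within the data shown here, the entering chain is the one compound 1 carries, and compound 1 sits at the limit. No step beyond the scatter is expected in this assay for compound 4, which is estimated at 300000 nM (100000 nM to 1000000 nM). This expected step from compound 3 is a step that the limit leaves unreadable from compound 3 to compound 4.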

Compound 4, half-maximal inhibitory concentration: 6760 nM
Beside the measured number, compound 4's estimate is 44-fold (1.65 log units) above it; measured number below the stated range.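

In this assay, the saturated chain carbon bound to a sulfur now shows a readable change: (4-methylphenyl)carbonyl gives an at least 29-fold lower number from compound 3 to compound 4 (1.47 log units; beyond the scatter) in place of 2-chlorophenyl, and an at least 29-fold lower number from compound 2 to compound 4 (1.47 log units; beyond the scatter) in place of vinyl. 3,4,5-Trimethoxyphenyl in place of ethyl on an aromatic carbon gives an at least 29-fold lower number from compound 1 to compound 4 (1.47 log units; beyond the scatter), so among these compounds a readable number appears only where both groups are present. These steps are minimum sizes because the other compounds stay at a limit: the limit of > 200000 nM in this assay, at which 3 of the 4 values shown sit.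

As far as these compounds go, whether the carbonyl or the 4-methylphenyl ring carries the step remains open. So does the effect of an amine or a carboxylic acid on that chain.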